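A Cyclohexyl Swap at the Ring Nitrogen

This account rests on a few compounds, and the source may have more. Where it says the series, first, only, none or still open, it means among the compounds named here.

Three compounds have been measured in a functional assay on brain (Rattus norvegicus, strain Wistar) for inhibition; a lower number here means a stronger inhibitor, a higher number a weaker inhibitor:

Compound 1 `Cc1ccc(-c2c(C)[nH]c(=O)n2C)cc1`: 85300 nM
Compound 2 `CCCCCCCc1ccc(-c2c(C)[nH]c(=O)n2C)cc1`: 8400 nM
Compound 3 `CCCCCCCCc1ccc(-c2c(C)[nH]c(=O)n2C)cc1`: 19400 nM

Compound 3 holds the second highest number of the three; its nearest neighbour is compound 2, with a 2.3-fold higher number from compound 2 to compound 3 (0.36 log units; beyond the scatter), and the furthest is compound 1, with a 4.4-fold lower number from compound 1 to compound 3 (0.64 log units; beyond the scatter). The remaining step, a 10-fold lower number from compound 1 to compound 2 (1.01 log units; beyond the scatter), concerns the same chain on the aromatic ring. Compound 4 `CCCCCCCCc1ccc(-c2c(C)[nH]c(=O)n2C2CCCCC2)cc1` differs from compound 3 in another place: cyclohexyl in place of methyl on an aromatic nitrogen. Among the measured compounds shown here, no measured step touches this nitrogen, so there is no direct precedent, and the expected step of a 1.3-fold lower number from compound 3 to compound 4 (0.11 log units; within the scatter) is best taken as none beyond the scatter, with a wide range. For compound 4 the estimate is 15000 nM, between 3000 nM and 80000 nM.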

Compound 4, half-maximal inhibitory concentration: 10300 nM
Estimate against measurement, compound 4: 1.5-fold (0.16 log units) above; measured number inside the range.
By their numbers in this assay, from the lowest: compounds 2, 4 and 3 (each within the scatter of the next, the first and the last beyond it); then compound 1.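

Putting cyclohexyl in place of methyl on the aromatic nitrogen gives a 1.9-fold lower number from compound 3 to compound 4 (0.27 log units; within the scatter) in this assay, the only change at this nitrogen among the compounds shown. A group of 6 heavy atoms with a non-aromatic ring thus replaces one of 1 heavy atom without a step beyond the scatter. Nothing measured here accounts for this result.

From the compounds shown here alone, whether ethyl, phenyl or a chain ending in an amine would behave the same way on this nitrogen stays open. So does whether cyclohexyl would give a similar step on the shorter chain of compound 2.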